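Fluorophenyl Takes the Place of the Pyrazole Ether

The source may hold more compounds than are shown below. What is called first, only, known or untested is meant among the compounds shown, and "the series" means these compounds.

Compound 1 `Cc1cc(C)n(CCOC2CC(=O)Nc3c2c(C)nn3-c2ncnc3nc[nH]c23)n1` stands highest of the two measured numbers: in a functional assay on HEK293 cells for agonist activity at G-protein coupled receptor 39 (Homo sapiens), read by scintillation proximity assay and inositol phosphate accumulation, with a stated time of 75 min (on this read-out higher numbers stand for an effect only at larger amounts of compound and lower numbers for an effect already at smaller amounts), compound 1 gives 2000 nM. Compound 2 `Cc1nn(-c2ncnc3nc[nH]c23)c2c1C(OCc1ccccc1C#N)CC(=O)N2` gives 127 nM, and the step of a 16-fold lower number from compound 1 to compound 2 (1.20 log units; beyond the scatter) is large. Compound 3 `Cc1nn(-c2ncnc3nc[nH]c23)c2c1C(OCc1ccc(F)cc1)CC(=O)N2` differs from compound 1 by 4-fluorophenyl in place of (3,5-dimethyl-1H-pyrazol-1-yl)methyl on a saturated chain carbon bound to an oxygen on a saturated carbon. Going by the values given here, only the step from compound 1 to compound 2 bears on this change, and it went strongly downward when an aromatic ring entered at the same place; compound 3 brings a different aromatic ring, so a downward step is expected here as well, roughly an 8.0-fold lower number from compound 1 to compound 3 (0.90 log units; beyond the scatter). Compound 3 is therefore estimated at 250 nM, with a range from 80 nM to 800 nM.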

Compound 3, half-maximal effective concentration: 126 nM
Beside the measured number, compound 3's estimate is 2.0-fold (0.30 log units) above it; low and high end bracket the measured number.
By their numbers in this assay, from the lowest: compounds 3 and 2 (each within the scatter of the next); then compound 1.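

In this assay 4-fluorophenyl gives a large step (a 16-fold lower number from compound 1 to compound 3 (1.20 log units; beyond the scatter)), so the earlier gain at this place is no longer tied to 2-cyanophenyl alone. The two phenyl groups cannot be told apart here (a 1.0-fold lower number from compound 2 to compound 3 (0.00 log units; within the scatter)). Nothing measured here explains either step. The compounds shown leave open whether an aromatic ring is needed on this saturated chain carbon at all, as a simple methyl or an amine could show. They also leave open how a carboxylic acid on the phenyl ring would read.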